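The compounds below may be only part of what the source reports. "The series", "measured", "known", "first", "only" and "open" are said of these compounds alone.

Working notes on the series. The common core is a pyrazolone carrying a benzimidazole on ring nitrogen, and the assay is an assay on isolated protein for inhibition of alpha-ketoglutarate-dependent dioxygenase alkB homolog 3 (Homo sapiens), read by polymerase chain reaction, with a stated time of 1 h; on this read-out higher numbers stand for weaker inhibition and lower numbers for stronger inhibition. Compound 1 `Cc1[nH]n(-c2nc3ccccc3[nH]2)c(=O)c1CC(=O)O` gives 15000 nM in this assay, the highest of the two numbers recorded. Compound 3 `Cc1ccc2[nH]c(-n3[nH]c(C)c(Cc4ccc(C(F)(F)F)cc4)c3=O)nc2c1`, which carries a 4-(trifluoromethyl)benzyl at the same position and a methyl on the benzimidazole, gives 570 nM, a lower number that lies beyond the scatter of the pair. Compound 2 `O=c1c(Cc2ccccc2)c(-c2ccccc2)[nH]n1-c1nc2ccccc2[nH]1`, with a benzyl and a phenyl in place of the methyl, reaches only a limit of this assay, > 10000 nM; it is one of the values sitting at that limit, as noted in the limit of > 10000 nM in this assay, at which 1 of the 3 values shown sits.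

The next compound, compound 4 `Cc1[nH]n(-c2nc3ccccc3[nH]2)c(=O)c1Cc1ccc(F)cc1`, is not yet measured. It differs from compound 1 in one place: 4-fluorophenyl in place of carboxy on a saturated chain carbon bound to an aromatic carbon, in words 4-fluorophenyl in place of carboxy on a saturated chain carbon bound to an aromatic carbon. Within the data shown here, no step between two measured compounds isolates this change, so any expectation rests on compound 3 and compound 2 together. Compound 3 shows that a para-substituted benzyl can sit with a low number; compound 2 shows that a benzyl alone does not guarantee one. The step from compound 1 to compound 4 is expected to lower the number, estimated at a 6.0-fold lower number from compound 1 to compound 4 (0.78 log units; beyond the scatter). For compound 4 the estimate in this assay is 2500 nM, with a range from 500 nM to 10000 nM.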

Compound 4, half-maximal inhibitory concentration: 600 nM
The estimate for compound 4 lay 4.2-fold (0.62 log units) above the measured number; low and high end bracket the measured number.
By their numbers in this assay, from the lowest: compounds 3 and 4 (each within the scatter of the next); then compound 1.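

In this assay, among these compounds, the change from carboxymethyl to 4-fluorobenzyl now stands alone in one place and comes to a 25-fold lower number from compound 1 to compound 4 (1.40 log units; beyond the scatter), a large step that the earlier compounds could not isolate because each of them differs from compound 1 in more than one place. The position on the saturated chain carbon bound to an aromatic carbon therefore accepts the loss of carboxy, with its hydrogen-bond donor and acceptor, and the entry of a six-membered aromatic ring of carbon only, with the rest of compound 1 unchanged. No measured property in the data shown bears on the cause of this step.

This single pair cannot separate the contribution of the aromatic ring from that of the fluorine, or show whether the loss of carboxy alone accounts for the step. Still open, as far as these compounds go, is how the position responds to a group such as an unsubstituted benzyl, a 4-methoxybenzyl, an aminomethyl or a longer chain ending in the 4-fluorophenyl, with the shared core and the methyl kept as in compound 4.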